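A few compounds are considered here, and "the series" means these few. Any claim that something is new, unique, unknown or untested is made for them only; others in the source may bear on it.

Working notes on the series. Compound 2 `COc1ccc(-c2cc(COc3ccccc3-c3nc4ccccc4s3)on2)cc1` carries methoxy on the para position of the pendant ring of the shared core; in a functional assay on COLO 205 cells (Homo sapiens) for cytotoxicity, read by MTT assay, with a stated time of 24 h (a lower number here means a stronger inhibitor, a higher number a weaker inhibitor), compound 2 gives 20700 nM. For the measured compounds named here, the only other number so far comes from compound 1 `Brc1ccc(-c2cc(COc3ccccc3-c3nc4ccccc4s3)on2)cc1`, which in this assay gives 16400 nM. Compound 2 thus has the higher of the two numbers, but the step of a 1.3-fold higher number from compound 1 to compound 2 (0.10 log units; within the scatter) lies within the scatter, so the two compounds cannot be told apart on these data.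

Compound 3 `Cc1ccc(-c2cc(COc3ccccc3-c3nc4ccccc4s3)on2)cc1` is the next member: methyl in place of methoxy on an aromatic carbon. Going by the values given here, the one measured step that bears on it is the exchange at the same para position, a 1.3-fold higher number from compound 1 to compound 2 (0.10 log units; within the scatter), which did not move the number beyond the scatter. On that basis a step of a 1.2-fold lower number from compound 2 to compound 3 (0.06 log units; within the scatter) is expected, that is, no change beyond the scatter. Compound 3 is therefore estimated at 18000 nM, with a range from 8000 nM to 40000 nM.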

Compound 3, half-maximal inhibitory concentration: 14200 nM
Compound 3: the middle estimate sits 1.3-fold (0.10 log units) above what was measured, within the range that was stated.
By their numbers in this assay, from the lowest: compounds 3, 1 and 2 (each within the scatter of the next).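

With methyl, this position has now carried three groups. In this assay the exchange of methoxy for methyl gives a 1.5-fold lower number from compound 2 to compound 3 (0.16 log units; within the scatter) and the exchange of bromo for methyl gives a 1.2-fold lower number from compound 1 to compound 3 (0.06 log units; within the scatter) so compound 1, compound 2 and compound 3 cannot be told apart, and the loss of the oxygen and the hydrogen-bond acceptor of methoxy moves the number no further than the scatter. No measurement bears on what lies behind these numbers.

Going by these compounds, whether an amine, a carboxylic acid or a longer chain at this position would take the number beyond the scatter remains open. The compounds shown differ only at this position, so the effect of changes elsewhere on the shared core also remains open.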